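The source may hold more compounds than are shown below. What is called first, only, known or untested is meant among the compounds shown, and "the series" means these compounds.

Measured so far in a functional assay on CH1 cells (Homo sapiens) for inhibition, read by sulforhodamine B assay, with a stated time of 96 h; on this read-out lower numbers stand for stronger inhibition of growth and higher numbers for weaker inhibition of growth: compound 1 `CC[C@H](Nc1nc(NCc2ccccn2)c2ncn(C(C)C)c2n1)C(C)(C)O` gives 26000 nM; compound 2 `CC[C@@H](Nc1nc(NCc2ccccn2)c2ncn(C(C)C)c2n1)C(O)C(C)(C)C` gives 27000 nM.

Compound 2 stands at the higher of the two numbers, with compound 1 nearest, and the step of a 1.0-fold higher number from compound 1 to compound 2 (0.02 log units; within the scatter) lies within the scatter. Compound 3 `CC[C@@H](Nc1nc(NCc2ccccn2)c2ncn(C(C)C)c2n1)C(C)(C)O` is the next step: 1-hydroxy-1-methylethyl in place of 1-hydroxy-2,2-dimethylpropyl on a saturated chain carbon bound to a nitrogen on an aromatic ring and a saturated chain carbon. It thus carries the same group as compound 1 on the nitrogen on the aromatic ring. Going by the values given here, the one step bearing on this change, a 1.0-fold higher number from compound 1 to compound 2 (0.02 log units; within the scatter), was flat, so no shift beyond the scatter is expected: no change at the digits printed from compound 2 to compound 3 (within the scatter). Compound 3 is estimated at 27000 nM in this assay, range 10000 nM to 70000 nM.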

Compound 3, concentration for 50% growth inhibition: > 50000 nM
Compound 3: no number, only a limit; the forecaster's own chance of this, stated with the estimate: 10%; middle value at least 1.8-fold (0.26 log units) from the limit.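

In this assay compound 3 gives > 50000 nM, which is a limit and not a number. The new steps are floors only, an at least 1.8-fold higher number from compound 2 to compound 3 (0.26 log units; that floor lies within the scatter) and an at least 1.9-fold higher number from compound 1 to compound 3 (0.28 log units; that floor lies within the scatter), so neither the smaller 1-hydroxy-1-methylethyl group nor the inverted stereocentre is shown to shift the read-out beyond the scatter. Compounds 1 and 3 give the first look at configuration at this saturated chain carbon, but the size of its effect stays unread: the fact that compounds 1 and 3 differ only in the configuration as drawn

From the compounds shown here alone, the true value of compound 3 remains open. So does the outcome of replacing the hydroxyl on this chain with an amine or a carboxylic acid.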